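Compound 4 after two level bridged analogues

The source may report more compounds than this note shows. Statements on the series, on what has been measured and on what is new or still open speak of the compounds shown alone.

Compounds measured in an ADME assay on microsomes from liver (Homo sapiens) for metabolic stability, read by LC-MS, with a stated time of 10 min; a higher number here means that more of the compound is left, a lower number that less of the compound is left:
Compound 1 `CN(C[C@H]1Cc2c(cccc2N2CCN(Cc3ccccn3)CC2)CN1)[C@H]1CCCc2cccnc21`: 4.2%
Compound 2 `CN(C[C@H]1Cc2c(cccc2N2C[C@@H]3C[C@H]2CN3)CN1)[C@H]1CCCc2cccnc21`: 100%
Compound 3 `CN(C[C@H]1Cc2c(cccc2N2C[C@H]3C[C@@H]2CN3)CN1)[C@H]1CCCc2cccnc21`: 100%

In this assay, compound 3 stands at 100%, level with compound 2 and together with it the highest of the three numbers, well clear of compound 1. The next compound, compound 4 `CN(C[C@H]1Cc2c(cccc2N2CCNCC2)CN1)[C@H]1CCCc2cccnc21`, has not yet been measured. It carries piperazin-1-yl on an aromatic carbon: a group of 6 heavy atoms (4 carbon, 2 nitrogen; one six-membered non-aromatic ring with 2 hetero atoms) in place of a group of 7 heavy atoms (5 carbon, 2 nitrogen; 2 five-membered non-aromatic rings with 1 hetero atom each), on an aromatic carbon.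

Among the compounds with values here, only one measured step is available, no change at the digits printed from compound 2 to compound 3 (within the scatter). It comes with the fact that compounds 2 and 3 differ only in the configuration as drawn, so it does not test a change of the group itself. Still, both configurations of that group gave the same number. Compound 1 at 4.2% shows that far lower numbers occur among these compounds, so the range stays wide on the low side.

An estimated a number 8 percentage points lower from compound 3 to compound 4 (within the scatter) is expected, which would lie within the scatter. For compound 4 the expected value is 92%, with an estimated range of 65% to 100%.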

Compound 4, percent of the compound remaining: 99.7%
For compound 4 the middle estimate is 7.7 percentage points below the measured one, and the stated range covers the measured number.
By their numbers in this assay, from the lowest: compound 1; then compounds 4, 2 and 3 (each within the scatter of the next).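

Measured in this assay the exchange of the bridged group for piperazin-1-yl on the aromatic carbon gives a number 0.3 percentage points lower from compound 3 to compound 4 (within the scatter) and a number 0.3 percentage points lower from compound 2 to compound 4 (within the scatter) so at this position the bridged group and the simple six-membered ring cannot be told apart. The earlier step could not test a change of the group itself, and the reason is this: the fact that compounds 2 and 3 differ only in the configuration as drawn. The step of a number 95.5 percentage points higher from compound 1 to compound 4 (beyond the scatter) now ties the large gap to a single change, hydrogen in place of (pyridin-2-yl)methyl on the amine nitrogen in the ring.

Going by these compounds, what remains open is whether a small group such as methyl or acetyl on that nitrogen would keep the number high. The compounds also leave open whether benzyl would behave as (pyridin-2-yl)methyl does, and they give no cause for the gap.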